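The source may hold more compounds than are shown below. What is called first, only, known or untested is meant among the compounds shown, and "the series" means these compounds.

Measured in a functional assay on HCT-116 cells (Homo sapiens) for cytotoxicity, read by MTT assay, with a stated time of 72 h; a higher number here means a weaker inhibitor, a lower number a stronger inhibitor:
- Compound 1 `O=C1c2c[n+]([O-])c3ccccc3c2C(=O)c2c1c1ccccc1n2CCCCn1ccnc1`: 240 nM
- Compound 2 `O=C1c2c[n+]([O-])c3ccccc3c2C(=O)c2c1c1ccccc1n2Cc1cn(C[C@H](O)CO)nn1`: 400 nM
- Compound 3 `O=C1c2c[n+]([O-])c3ccccc3c2C(=O)c2c1c1ccccc1n2Cc1cn(CC(O)CO)nn1`: 250 nM

All three values lie within the scatter of one another, so compound 3, at 250 nM, stands level with the other two. Compound 4 `CN1CCN(CCCCn2c3c(c4ccccc42)C(=O)c2c[n+]([O-])c4ccccc4c2C3=O)CC1` carries 3-(4-methylpiperazin-1-yl)propyl in place of 1-(2,3-dihydroxypropyl)-1H-1,2,3-triazol-4-yl on a saturated chain carbon bound to an aromatic nitrogen. Two measured steps exchange groups at this same place: a 1.7-fold higher number from compound 1 to compound 2 (0.22 log units; within the scatter) and a 1.0-fold higher number from compound 1 to compound 3 (0.02 log units; within the scatter). Among the compounds with values here, neither leaves the scatter, so no step beyond it is expected in this assay, although no measured compound carries the new group. The expected change is a 1.1-fold lower number from compound 3 to compound 4 (0.04 log units; within the scatter). For compound 4 the estimated value is 230 nM, with an expected range of 90 nM to 600 nM.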

Compound 4, half-maximal inhibitory concentration: 10 nM
Compound 4: middle estimate off by 23-fold (1.36 log units), on the high side, and the stated range ends above it.
By their numbers in this assay, from the lowest: compound 4; then compounds 1, 3 and 2 (each within the scatter of the next).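

In this assay the group on a saturated chain carbon bound to an aromatic nitrogen proves able to move the number beyond the scatter, which no earlier exchange there did: 3-(4-methylpiperazin-1-yl)propyl in place of 1-(2,3-dihydroxypropyl)-1H-1,2,3-triazol-4-yl gives a 25-fold lower number from compound 3 to compound 4 (1.40 log units; beyond the scatter) and a 40-fold lower number from compound 2 to compound 4 (1.60 log units; beyond the scatter) for the same exchange. The chain-end exchange alone, 4-methylpiperazin-1-yl in place of 1H-imidazol-1-yl, gives a 24-fold lower number from compound 1 to compound 4 (1.38 log units; beyond the scatter) as a step of similar size. Within the data shown here, the only evidence at hand concerns the drawn configuration of compounds 2 and 3 and does not bear on this result.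

The compounds shown leave open whether a morpholine or a dimethylamine at the end of the same chain would match 4-methylpiperazin-1-yl. They also leave open whether a shorter or longer chain would keep the number of compound 4.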